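Ester group variation and inhibition in a small series

The compounds below may be only part of what the source reports. "The series", "measured", "known", "first", "only" and "open" are said of these compounds alone.

Measured compounds:
compound 1, `COc1cc(O)c(C(=O)OCC(C)c2ccccc2)c(/C=C/CN2C(=O)C=CC2=O)c1`: 8.6%
compound 2, `COc1cc(O)c(C(=O)OC(C)C)c(/C=C/CN2C(=O)C=CC2=O)c1`: 5.4%

Both numbers come from an assay on isolated protein for inhibition of MAP kinase-interacting serine/threonine-protein kinase 1 (Homo sapiens), tested at 10 uM; on this read-out higher numbers stand for more inhibition at the one concentration tested (going by the name of the read-out) and lower numbers for less inhibition. Going by the values given here, compound 2 holds the lower of the two, though the only comparison available, a number 3.2 percentage points lower from compound 1 to compound 2 (within the scatter), lies within the scatter, so the two compounds cannot be told apart on this read-out. Among the compounds with values here, the one measured step therefore says only that exchanging the group on the oxygen next to the carbonyl has, so far, produced no change that can be trusted.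

Compound 3, `COc1cc(O)c(C(=O)OCC2CCCCC2)c(/C=C/CN2C(=O)C=CC2=O)c1`, is not yet measured. It differs from compound 2 by cyclohexylmethyl in place of isopropyl on an oxygen next to a carbonyl group. The step from compound 1 to compound 2 is the only measured one that touches the same position, and it stayed within the scatter. On that basis the step to compound 3 is expected to stay within the scatter as well, estimated as a number 1.6 percentage points higher from compound 2 to compound 3 (within the scatter). Compound 3 is therefore expected to give about 7%, with a range from -5% to 20%.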

Compound 3, a percentage reported as inhibition, at one concentration (the size of the read-out at that concentration, not a potency): 9.7%
The estimate for compound 3 lay 2.7 percentage points below the measured number; the range from low to high includes it.
By their numbers in this assay, from the lowest: compounds 2, 1 and 3 (each within the scatter of the next).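

Across isopropyl, 2-phenylpropyl and cyclohexylmethyl, a wider range of groups at this position now gives no change that can be trusted in this assay: cyclohexylmethyl in place of isopropyl on an oxygen next to a carbonyl group, with 7 carbon atoms entering and 3 leaving, gives a number 4.3 percentage points higher from compound 2 to compound 3 (within the scatter), so neither the added carbon count nor the six-membered non-aromatic ring separates the two compounds. The second new step, cyclohexyl in place of 1-phenylethyl on a saturated chain carbon bound to an oxygen next to a carbonyl group, gives a number 1.1 percentage points higher from compound 1 to compound 3 (within the scatter), so a group carrying a phenyl ring and one carrying a cyclohexyl ring cannot be told apart on this read-out. No independent measurement is available to account for these numbers.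

As far as these compounds go, what remains open is whether any group on this oxygen can move the read-out beyond the scatter, since all three compounds stay within it of one another. Esters whose chain carries an amine or a carboxylic acid, and an amide in place of the ester, remain untested in the compounds shown here.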